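This account rests on a few compounds, and the source may have more. Where it says the series, first, only, none or still open, it means among the compounds named here.

Measured compounds in a functional assay on DU-145 cells (Homo sapiens) for cytotoxicity, read by MTT assay; a lower number here means a stronger inhibitor, a higher number a weaker inhibitor:
compound 1, `CC[C@@](C)(O)CC(=O)O[C@H](CC=C(C)C)C1=CC(=O)c2c(O)ccc(O)c2C1=O`: 12700 nM
compound 2, `CC(C)=CC[C@@H](OC(=O)C1CCCCO1)C1=CC(=O)c2c(O)ccc(O)c2C1=O`: 24700 nM
compound 3, `CCC(CO[C@H](CC=C(C)C)C1=CC(=O)c2c(O)ccc(O)c2C1=O)OC(C)=O`: 25400 nM

Compound 3 gives the highest of the three numbers, but its steps to the others, a 2.0-fold higher number from compound 1 to compound 3 (0.30 log units; within the scatter) and a 1.0-fold higher number from compound 2 to compound 3 (0.01 log units; within the scatter), both lie within the scatter, so no order among them can be drawn. Compound 4, `CC[C@](C)(O)CC(=O)O[C@H](CC=C(C)C)C1=CC(=O)c2c(O)ccc(O)c2C1=O`, is not yet measured. Its change from compound 3 is (2-hydroxy-2-methylbutyl)carbonyl in place of 2-acetoxybutyl on an oxygen on a saturated carbon. Among the compounds with values here, the one measured step that bears on this is the reverse one, a 2.0-fold higher number from compound 1 to compound 3 (0.30 log units; within the scatter), which stayed within the scatter. The same exchange run back is therefore expected to give a 2.0-fold lower number from compound 3 to compound 4 (0.29 log units; within the scatter), a step still within the scatter. Compound 4 is thus expected at about 13000 nM, with a range from 5000 nM to 35000 nM.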

Compound 4, half-maximal inhibitory concentration: 20500 nM
The estimate for compound 4 lay 1.6-fold (0.20 log units) below the measured number, within the range that was stated.
By their numbers in this assay, from the lowest: compounds 1, 4, 2 and 3 (each within the scatter of the next).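

A stereocentre at a saturated chain carbon now has a reading of its own in this assay: going from R to S gives a 1.6-fold higher number from compound 1 to compound 4 (0.21 log units; within the scatter). That step reads on configuration alone: the fact that compounds 1 and 4 differ only in the configuration as drawn

With the S configuration, the side group also stays within the scatter of the other two, giving a 1.2-fold lower number from compound 3 to compound 4 (0.09 log units; within the scatter) against 2-acetoxybutyl and a 1.2-fold lower number from compound 2 to compound 4 (0.08 log units; within the scatter) against oxan-2-yl.

Since every step here lies within the scatter, the compounds shown do not reveal which change at this position, if any, would move the number. On these data alone, whether an amine or a carboxylic acid in place of the hydroxy group of the 2-hydroxy-2-methylbutyl chain would do so remains open.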